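A few compounds are considered here, and "the series" means these few. Any claim that something is new, unique, unknown or untested is made for them only; others in the source may bear on it.

Compound 2 `CCCn1c(=O)[nH]c2nc(-c3ccc(S(=O)(=O)N4CCN(Cc5cccc(Br)c5)CC4)cc3)[nH]c2c1=O` in an assay on CHO cells for displacement of a labelled ligand from adenosine receptor A3 (Homo sapiens), read by scintillation counting, with a stated time of 45 min, in the presence of a further agent that is not named here (on this read-out higher numbers stand for weaker inhibition and lower numbers for stronger inhibition), gives > 1000 nM, which is a limit of the assay rather than a number. Its companion compound 1 `CCCn1c(=O)[nH]c2nc(-c3ccc(S(=O)(=O)N4CCN(c5ccc(Cl)cc5F)CC4)cc3)[nH]c2c1=O` in this assay gives > 1000 nM, likewise a limit. The step that the two limits leave unreadable from compound 1 to compound 2 is therefore not readable as a size. Compound 3 `CCCn1c(=O)[nH]c2nc(-c3ccc(S(=O)(=O)N4CCN(c5ccccc5Br)CC4)cc3)[nH]c2c1=O` differs from compound 2 by 2-bromophenyl in place of 3-bromobenzyl on an amine nitrogen in a ring. Among the compounds with values here, both measured values sit at the limit of > 1000 nM in this assay, at which 2 of the 2 values shown sit, so no measured step bears readably on this change, and no direction can be taken from them. Compound 3 is therefore expected to give 2500 nM, within the range 600 nM to 15000 nM. That estimate means an expected step that the limit leaves unreadable from compound 2 to compound 3.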

Compound 3, inhibition constant: > 1000 nM
Compound 3 gave a limit, no number; the forecaster's own chance of this, stated with the estimate: 70%; the middle value is on the limit's open side.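

Compound 3 gives only a limit in this assay, as do compound 1 and compound 2, so no step among them can be read: the limit of > 1000 nM in this assay, at which 3 of the 3 values shown sit.

The compounds shown leave open whether these groups on the amine nitrogen in a ring differ at all in this assay.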